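The compounds below may be only part of what the source reports. "The series", "measured", "known", "first", "only" and "open" are said of these compounds alone.

Compound 1 `Brc1c(Nc2ncc[nH]2)ccc2nccnc12` returns only a limit of the assay in an assay on Cerebral cortex for displacement of a labelled ligand from Adrenergic receptor alpha-1 (Homo sapiens) (a lower number here means a stronger inhibitor, a higher number a weaker inhibitor), > 100000 nM, which is the limit of > 100000 nM in this assay, at which 1 of the 3 values shown sits. Compound 2 `Clc1cccc(Cl)c1Nc1ncc[nH]1` gives 6000 nM in this assay. Compound 3 `Cc1c(Nc2ncc[nH]2)ccc2nccnc12` likewise returns only a limit in this assay, > 28000 nM, which is the limit of > 28000 nM in this assay, at which 1 of the 3 values shown sits. Compound 3 thus stands at a limit with no number, and the step that the two limits leave unreadable from compound 1 to compound 3 stays unreadable, a limit sitting at each end. Compound 4 `c1c[nH]c(Nc2ccc3nccnc3c2)n1` differs from compound 3 by hydrogen in place of methyl on an aromatic carbon. Among the compounds with values here, no measured step covers a change of this kind on the shared core; the single step there is unreadable, and compound 2 sits on another core. Nothing points to a shift beyond the scatter, so the step that the limit leaves unreadable from compound 3 to compound 4 is expected to be small. Compound 4 is estimated at 30000 nM, with a range from 5000 nM to 200000 nM, and a limit rather than a number is a likely outcome.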

Compound 4, inhibition constant: > 100000 nM
Compound 4: no number, only a limit; the forecaster's own chance of this, stated with the estimate: 60%; at least 3.3-fold (0.52 log units) between middle value and limit.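

Compound 4 returns only a limit, > 100000 nM, so its steps from compound 3 and compound 1 cannot be read. The compounds shown leave open whether bromo, methyl and hydrogen on this aromatic carbon differ at all.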